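Replacing 4-methoxyphenyl with 2-chlorophenyl in an antiproliferative series

This account rests on a few compounds, and the source may have more. Where it says the series, first, only, none or still open, it means among the compounds named here.

- compound 1 `COc1ccc(OCCCON2C(N)=NC(N)=NC23CCOCC3)cc1` gives "not determined" (no result reported)
- compound 2 `NC1=NC2(CCSCC2)N(OCCCOc2cccc(Cl)c2)C(N)=N1` gives 90 nM

On these data alone, in a functional assay on HepG2 cells (Homo sapiens) for antiproliferative activity, read by MTT assay, with a stated time of 72 h (on this read-out lower numbers stand for stronger inhibition and higher numbers for weaker inhibition), compound 1 has no single number, so its standing remains open. Compound 3 `NC1=NC2(CCOCC2)N(OCCCOc2ccccc2Cl)C(N)=N1`, still unmeasured, carries 2-chlorophenyl in place of 4-methoxyphenyl on an oxygen on a saturated carbon and so departs from compound 1 in that one place. For the measured compounds named here, no step between measured compounds exists, so no direction can be given in this assay and no step beyond the usual scatter is expected. Going by the values given here, the only measured guide is compound 2 at 90 nM for now. Compound 3 is estimated at 120 nM with an expected range from 30 nM to 500 nM for the coming measurement.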

Compound 3, half-maximal inhibitory concentration: 1750 nM
Beside the measured number, compound 3's estimate is 15-fold (1.16 log units) below it, and the stated range ends below it.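

For the compounds shown here, compound 3 gives 1750 nM, but compound 1 has no single number, so no step between compound 1 and compound 3 can be read. On these data alone, what 2-chlorophenyl in place of 4-methoxyphenyl does to activity stays open. No measured evidence bears on this result.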